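The compounds below may be only part of what the source reports. "The series", "measured", "known", "first", "only" and "open" are said of these compounds alone.

In an ADME assay on RAW264.7 cells (Mus musculus) for cytotoxicity, read by MTT assay, with a stated time of 24 h (a lower number here means a stronger inhibitor, a higher number a weaker inhibitor), three compounds have been measured so far.

Compound 1 `O=C(OCC#Cc1cnc2ccccc2n1)c1ccccc1` gives 55600 nM.
Compound 2 `O=C(OCC#Cc1cnc2cc(Cl)ccc2n1)c1ccccc1` gives 82300 nM.
Compound 3 `O=C(OCC#Cc1cnc2ccccc2n1)c1cccs1` gives 39000 nM.

Compound 2 differs from compound 1 by chloro in place of hydrogen on an aromatic carbon, and that change produced a 1.5-fold higher number from compound 1 to compound 2 (0.17 log units; within the scatter). Compound 3 differs from compound 1 in a different way, by thiophen-2-yl in place of phenyl on a carbonyl carbon, and that change produced a 1.4-fold lower number from compound 1 to compound 3 (0.15 log units; within the scatter).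

Compound 4 `O=C(OCC#Cc1cnc2cc(Cl)ccc2n1)c1cccs1` has not yet been measured. It differs from compound 3 by chloro in place of hydrogen on an aromatic carbon, the same change already seen from compound 1 to compound 2, at a place described in the same words. On that basis, from compound 3 to compound 4 a 1.5-fold higher number from compound 3 to compound 4 (0.17 log units; within the scatter) is expected in this assay, resting on the step of a 1.5-fold higher number from compound 1 to compound 2 (0.17 log units; within the scatter). Compound 4 is therefore estimated at 58000 nM, most likely between 30000 nM and 110000 nM.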

Compound 4, half-maximal inhibitory concentration: 11300 nM
Estimate against measurement, compound 4: 5.1-fold (0.71 log units) above, and the stated range ends above it.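

In this assay, the chloro change did not carry over from one core to the other, since here it gave a 3.5-fold lower number from compound 3 to compound 4 (0.54 log units; beyond the scatter), which differs from the earlier step: the same change on two cores in this assay, a 1.5-fold higher number (0.17 log units; within the scatter) from compound 1 to compound 2 and a 3.5-fold lower number (0.54 log units; beyond the scatter) from compound 3 to compound 4, 5.1-fold (0.71 log units) apart, beyond the scatter of two such steps

Seen from the other side, thiophen-2-yl in place of phenyl gave a 7.3-fold lower number from compound 2 to compound 4 (0.86 log units; beyond the scatter) on the core carrying chloro, which also differs from the step on the core without it: the same change on two cores in this assay, a 1.4-fold lower number (0.15 log units; within the scatter) from compound 1 to compound 3 and a 7.3-fold lower number (0.86 log units; beyond the scatter) from compound 2 to compound 4, 5.1-fold (0.71 log units) apart, beyond the scatter of two such steps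

So in these four compounds the effect of each change depends on the other, but this rests on a single set of four compounds and does not show why.

On these data alone, whether a bromo or methoxy group in place of chloro would behave the same way remains open. So does whether a furan-2-yl group in place of thiophen-2-yl would show the same dependence.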